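Chloro for methoxy on the anilide of a chromone acrylamide

The source may hold more compounds than are shown below. What is called first, only, known or untested is meant among the compounds shown, and "the series" means these compounds.

Measured compounds:
compound 1 `COc1ccc(CNC(=O)/C=C/c2coc3cc(OC)ccc3c2=O)cc1` — 7570 nM
compound 2 `COc1ccc2c(=O)c(/C=C/C(=O)NCc3ccc(F)cc3)coc2c1` — 21000 nM
compound 3 `COc1ccc2c(=O)c(/C=C/C(=O)Nc3ccccc3OC)coc2c1` — 32300 nM

In a functional assay on Huh-7 cells (Homo sapiens) for inhibition, read by MTT assay, with a stated time of 48 h (on this read-out lower numbers stand for stronger inhibition and higher numbers for weaker inhibition), compound 3 gives the highest of the three numbers; compound 2 is within the scatter of it, while compound 1 lies well below. Compound 4 `COc1ccc2c(=O)c(/C=C/C(=O)Nc3ccccc3Cl)coc2c1` differs from compound 3 by chloro in place of methoxy on an aromatic carbon. Among the compounds with values here, the only measured step that bears on this is a 2.8-fold higher number from compound 1 to compound 2 (0.44 log units; beyond the scatter), where a halogen replaced a methoxy group on an aromatic carbon of the amide substituent and the number rose. On that basis a modest rise, or no change beyond the scatter, is expected in this assay, as a 1.4-fold higher number from compound 3 to compound 4 (0.14 log units; within the scatter). Compound 4 is therefore estimated at 45000 nM, within 16000 nM to 120000 nM.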

Compound 4, half-maximal inhibitory concentration: 58400 nM
Compound 4: middle estimate off by 1.3-fold (0.11 log units), on the low side, and the stated range covers the measured number.
By their numbers in this assay, from the lowest: compound 1; then compounds 2, 3 and 4 (each within the scatter of the next, the first and the last beyond it).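

In this assay, chloro in place of methoxy on this aromatic carbon, ortho to a large group, leaves the number within the scatter (a 1.8-fold higher number from compound 3 to compound 4 (0.26 log units; within the scatter)), so the two groups are not told apart here. With chloro, the 2-chlorophenyl amide is separated beyond the scatter from both the 4-fluorobenzyl amide (a 2.8-fold higher number from compound 2 to compound 4 (0.44 log units; beyond the scatter)) and the 4-methoxybenzyl amide (a 7.7-fold higher number from compound 1 to compound 4 (0.89 log units; beyond the scatter)). Nothing available explains these steps. Open, going by these compounds, is whether an amine or a carboxylic acid on this aromatic carbon would shift the number, and whether chloro would act likewise on the benzyl amides.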